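Replacing the 4-Hydroxyphenyl Group of Compound 2

The compounds below may be only part of what the source reports. "The series", "measured", "known", "first", "only" and "open" are said of these compounds alone.

In a functional assay on HepG2 cells (Homo sapiens) for antiproliferative activity, read by MTT assay, with a stated time of 72 h (on this read-out higher numbers stand for weaker inhibition and lower numbers for stronger inhibition), compound 1 `O=C(N/N=C/c1ccc(Br)cc1)Nc1ccc(Oc2ccnc3[nH]ccc23)cc1` gives 1000 nM while compound 2 `O=C(N/N=C/c1ccc(O)cc1)Nc1ccc(Oc2ccnc3[nH]ccc23)cc1` gives 32200 nM as the higher of the two numbers, so compound 2 is the weaker inhibitor of this pair. Among the measured compounds shown here, the one measured step is a 32-fold higher number from compound 1 to compound 2 (1.51 log units; beyond the scatter) and it comes from hydroxy in place of bromo on an aromatic carbon.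

For the measured compounds named here, compound 3 `CN(C)CCCn1cccc1/C=N/NC(=O)Nc1ccc(Oc2ccnc3[nH]ccc23)cc1` loses the whole 4-hydroxyphenyl group of compound 2, not just its hydroxy: 1-(3-(dimethylamino)propyl)-1H-pyrrol-2-yl in place of 4-hydroxyphenyl on a carbon with a double bond to nitrogen and no measured compound carries a pyrrole or a dimethylamino chain, so the data offer no direct guide. The only clue is indirect. That single large step shows that a change on this aromatic group can shift the number strongly in this assay and compound 2 holds the higher of the two values, which makes a lower number the likelier direction. The expected change is a 5.4-fold lower number from compound 2 to compound 3 (0.73 log units; beyond the scatter) and this remains an estimate with wide uncertainty. Compound 3 is therefore expected near 6000 nM within an estimated range of 1200 nM to 30000 nM once measured.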

Compound 3, half-maximal inhibitory concentration: 4190 nM
For compound 3 the middle estimate is 1.4-fold (0.16 log units) above the measured one; low and high end bracket the measured number.
By their numbers in this assay, from the lowest: compound 1; then compound 3; then compound 2.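

In this assay, the group on the carbon with a double bond to nitrogen need not be a six-membered aromatic ring of carbon only. Putting 1-(3-(dimethylamino)propyl)-1H-pyrrol-2-yl in place of 4-hydroxyphenyl gives a 7.7-fold lower number from compound 2 to compound 3 (0.89 log units; beyond the scatter), so a five-membered aromatic ring with 1 hetero atom, carrying a chain, does better here than the 4-hydroxyphenyl group, although it does not match the 4-bromophenyl group: swapping that group for the same pyrrole gives a 4.2-fold higher number from compound 1 to compound 3 (0.62 log units; beyond the scatter), which leaves compound 1 with the lowest number of the three and shows that this position can place a very different group between the two earlier ones. No measurement at hand explains either step.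

As far as these compounds go, the pyrrole ring and the 3-(dimethylamino)propyl chain enter as a single change, so how much of the step belongs to each remains open. A pyrrole with only a methyl group on its nitrogen, a shorter or longer chain ending in the same amine, or a chain ending in a morpholine or a carboxylic acid would be needed to separate the ring from the chain and to show which part of the new group sets the number.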